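Swapping 2-methoxyphenyl for 4-fluorophenyl in compound 1

The compounds below may be only part of what the source reports. "The series", "measured", "known", "first", "only" and "open" are said of these compounds alone.

Compound 1 (`COc1ccccc1/C=C/C(=O)OC/C=C/c1cc(OC)c(OC)cc1OC`) is the starting point here. In a functional assay on the whole organism (strain Kunming) with Mus musculus as the target, in the formalin test, with a stated time of 0.5 h (a higher number here means that more compound is needed for the effect, a lower number that less compound is needed), compound 1 gives 113 mg/kg as its measured value. Compound 3 (`COc1cc(OC)c(OC)cc1/C=C/COC(=O)/C=C/c1ccccc1C(F)(F)F`) gives 123 mg/kg, which lies within the scatter of compound 1, so the two stand level on the numbers available. Compound 2 (`COc1cc(OC)c(OC)cc1/C=C/COC(=O)/C=C/c1c(OC)ccc(OC)c1OC`) is reported only as a limit, <= 80 mg/kg, and not as an exact number.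

Compound 4 (`COc1cc(OC)c(OC)cc1/C=C/COC(=O)/C=C/c1ccc(F)cc1`) has not yet been measured. It differs from compound 1 in one place: 4-fluorophenyl in place of 2-methoxyphenyl on a double-bonded chain carbon bound to a double-bonded chain carbon. In words, 4-fluorophenyl stands in place of 2-methoxyphenyl on a double-bonded chain carbon bound to a double-bonded chain carbon.

Going by the values given here, only one measured step bears on this change. Trifluoromethyl in place of methoxy on an aromatic carbon gave a 1.1-fold higher number from compound 1 to compound 3 (0.04 log units; within the scatter), so altering that end of the molecule did not move the result beyond normal repeat variation. Among the compounds with values here, no measured compound carries 4-fluorophenyl, which leaves this expectation resting on a single comparison. The expected step is a 1.0-fold lower number from compound 1 to compound 4 (0.01 log units; within the scatter), which means no real change is anticipated in this assay. Compound 4 is expected at about 110 mg/kg. The estimated range for compound 4 runs from 60 mg/kg to 200 mg/kg.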

Compound 4, dose for half-maximal effect: 43.4 mg/kg
Estimate against measurement, compound 4: 2.5-fold (0.40 log units) above, and the stated range ends above it.
By their numbers in this assay, from the lowest: compound 4; then compounds 1 and 3 (each within the scatter of the next).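

The change at this end of the molecule does matter: in this assay, 4-fluorophenyl in place of 2-methoxyphenyl on a double-bonded chain carbon bound to a double-bonded chain carbon gives a 2.6-fold lower number from compound 1 to compound 4 (0.42 log units; beyond the scatter), so less compound is needed for the effect. Replacing 2-(trifluoromethyl)phenyl with 4-fluorophenyl gives a similar result, a 2.8-fold lower number from compound 3 to compound 4 (0.45 log units; beyond the scatter), whereas the earlier exchange of methoxy for trifluoromethyl gave only a 1.1-fold higher number from compound 1 to compound 3 (0.04 log units; within the scatter), which makes compound 4 the compound needing the least among the three with exact numbers. No measurement shown gives a reason for this drop.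

As far as these compounds go, compound 2 is reported only as a limit, so the steps involving it cannot be read: the limit of <= 80 mg/kg in this assay, at which 1 of the 4 values shown sits. It stays open whether the result depends on the fluorine itself or simply on the loss of 2-methoxyphenyl, and how an amine or a carboxylic acid on the same phenyl ring would compare with 4-fluorophenyl in this assay.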